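Dithiocarbamate benzamide series: amine exchange at the thiocarbonyl

The source may hold more compounds than are shown below. What is called first, only, known or untested is meant among the compounds shown, and "the series" means these compounds.

Two compounds of the series have numbers in a functional assay on A-375 cells (Homo sapiens) for antiproliferative activity, read by CCK-8 assay, with a stated time of 72 h, tested at 8 uM; on this read-out higher numbers stand for a stronger effect at the one concentration tested and lower numbers for a weaker effect. Compound 1 `Nc1ccccc1NC(=O)c1ccc(CSC(=S)N2CCN(C(c3ccccc3)c3ccccc3)CC2)cc1` gives 8.4%. Compound 2 `Nc1ccccc1NC(=O)c1ccc(CSC(=S)N2CCc3ccccc32)cc1` gives 85.4%, the higher of the two numbers, with compound 1 far below it, a gap beyond the scatter. Among the measured compounds shown here, no step between these two is computed, as they differ in more than one place; their two values only show that the pair stands far apart on this read-out.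

Compound 3 `CN(C(=S)SCc1ccc(C(=O)Nc2ccccc2N)cc1)c1cccnc1` has not yet been measured in this assay. It differs from compound 2 in one place: methyl(pyridin-3-yl)amino in place of 2,3-dihydro-1H-indol-1-yl on a thiocarbonyl carbon. For the measured compounds named here, no measured pair shows what this exchange does, so the size of the step is open and the expectation rests on the spread already seen. The expected step is a number 30.4 percentage points lower from compound 2 to compound 3 (beyond the scatter), downward and of moderate size, with wide uncertainty. The estimate for compound 3 is 55%, with a range from 20% to 85%.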

Compound 3, a percentage reported as inhibition, at one concentration (the size of the read-out at that concentration, not a potency): 87.7%
Estimate against measurement, compound 3: 32.7 percentage points below; the whole stated range lies below it.
By their numbers in this assay, from the lowest: compound 1; then compounds 2 and 3 (each within the scatter of the next).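

In this assay, putting methyl(pyridin-3-yl)amino in place of 2,3-dihydro-1H-indol-1-yl on a thiocarbonyl carbon gives a number 2.3 percentage points higher from compound 2 to compound 3 (within the scatter), so this pair shows the position accepting a real change of group without a change in the read-out. The five-membered non-aromatic ring that leaves is thus not needed for the read-out in this pair, and a six-membered aromatic ring with one hetero atom, carried with a methyl group on the same nitrogen, serves equally well. Nothing at hand says why the two groups match here.

Going by these compounds, both numbers come from one concentration, so whether compound 2 and compound 3 would differ in the strength of their effect at any other concentration stays open. Also open, on these data alone, is how a simple dimethylamino group or a morpholine ring would behave on the same thiocarbonyl carbon.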